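Fluoro to Trifluoromethyl: Expecting Compound 4

A few compounds are considered here, and "the series" means these few. Any claim that something is new, unique, unknown or untested is made for them only; others in the source may bear on it.

Compound 1 `COc1ccc(-c2ccc3c(c2)C(=O)C(=O)N3C)cc1` gives 6670 nM in a functional assay on HepG2 cells (Homo sapiens) for antiproliferative activity, read by MTT assay, with a stated time of 48 h; on this read-out lower numbers stand for stronger inhibition and higher numbers for weaker inhibition. Compound 2 `COc1ccc(-c2ccc3c(c2)C(=O)C(=O)N3Cc2ccc(F)cc2)cc1` gives 1120 nM, a change of a 6.0-fold lower number from compound 1 to compound 2 (0.77 log units; beyond the scatter). Compound 3 `COc1ccc(-c2ccc3c(c2)C(=O)C(=O)N3Cc2ccc(Br)cc2)cc1` gives 700 nM, with a 9.5-fold lower number from compound 1 to compound 3 (0.98 log units; beyond the scatter) and a 1.6-fold lower number from compound 2 to compound 3 (0.20 log units; within the scatter). Among these three numbers compound 2 stands second highest, closest to compound 3 and furthest from compound 1. Compound 4 `COc1ccc(-c2ccc3c(c2)C(=O)C(=O)N3Cc2ccc(C(F)(F)F)cc2)cc1` differs from compound 2 by trifluoromethyl in place of fluoro on an aromatic carbon. Among the measured compounds shown here, the one measured step at the same place, bromo in place of fluoro, stayed within the scatter, so the larger change to trifluoromethyl is expected to move the number only a little, if at all, possibly downward. Compound 4 is therefore estimated at 850 nM, between 350 nM and 2000 nM, an expected step of a 1.3-fold lower number from compound 2 to compound 4 (0.12 log units; within the scatter).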

Compound 4, half-maximal inhibitory concentration: 380 nM
Estimate against measurement, compound 4: 2.2-fold (0.35 log units) above, within the range that was stated.
By their numbers in this assay, from the lowest: compounds 4, 3 and 2 (each within the scatter of the next, the first and the last beyond it); then compound 1.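

In this assay, a change at this ring carbon can reach beyond the scatter: trifluoromethyl in place of fluoro gives a 2.9-fold lower number from compound 2 to compound 4 (0.47 log units; beyond the scatter) and so does more than bromo in place of fluoro did. Trifluoromethyl and bromo cannot be told apart, with a 1.8-fold lower number from compound 3 to compound 4 (0.27 log units; within the scatter) staying within the scatter. The full 4-(trifluoromethyl)phenyl group gives an 18-fold lower number from compound 1 to compound 4 (1.24 log units; beyond the scatter) as the widest step in this set. As far as these compounds go, whether an amine or a carboxylic acid at this ring carbon would keep the number this low remains open. Nothing available explains these differences.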